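This account rests on a few compounds, and the source may have more. Where it says the series, first, only, none or still open, it means among the compounds named here.

Compound 3 `CCCC[C@]1(CO)NC[C@@H](O)[C@@H]1O` gives 16000 nM in an assay on isolated protein for inhibition of lysosomal alpha-glucosidase (Rattus norvegicus), read by colorimetric assay (on this read-out higher numbers stand for weaker inhibition and lower numbers for stronger inhibition), the highest of the three numbers recorded; compound 2 `C[C@@]1(CO)NC[C@H](O)[C@H]1O` gives 2900 nM and compound 1 `CCCCCCCCC[C@@]1(CO)NC[C@H](O)[C@H]1O` gives 960 nM, both beyond the scatter below it. Compound 4 `CCCC[C@@]1(CO)NC[C@H](O)[C@H]1O` has not yet been measured. Compound 4 differs from compound 3 only in configuration: the two compounds have the same atoms and bonds and differ only in configuration as drawn: 3 of 3 stereo elements differ (all stereocentres are inverted: mirror images); a stereocentre at a saturated ring carbon is drawn R in compound 3 and S in compound 4; a stereocentre at a saturated ring carbon is drawn R in compound 3 and S in compound 4; a stereocentre at a saturated ring carbon is drawn R in compound 3 and S in compound 4. Compound 4 shares its drawn configuration with compound 1 and compound 2, which are both well below compound 3. On that basis the number is expected to fall, and the step from compound 3 to compound 4 is estimated at an 8.0-fold lower number from compound 3 to compound 4 (0.90 log units; beyond the scatter), beyond the scatter, because compound 2 gives 2900 nM and compound 1 gives 960 nM. Compound 4 is therefore expected at about 2000 nM, within a range of 700 nM to 6000 nM.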

Compound 4, half-maximal inhibitory concentration: 220 nM
Beside the measured number, compound 4's estimate is 9.1-fold (0.96 log units) above it; measured number below the stated range.
By their numbers in this assay, from the lowest: compound 4; then compound 1; then compound 2; then compound 3.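

In this assay, configuration alone has a large effect at this position, with no atom or bond changed, and the result is a 73-fold lower number from compound 3 to compound 4 (1.86 log units; beyond the scatter); the gap can be traced to stereochemistry alone: the fact that compounds 3 and 4 differ only in the configuration as drawn

Within the shared configuration, the number does not run one way with chain length: propyl in place of hydrogen gives a 13-fold lower number from compound 2 to compound 4 (1.12 log units; beyond the scatter), and hydrogen in place of pentyl gives a 4.4-fold lower number from compound 1 to compound 4 (0.64 log units; beyond the scatter).

Compounds 3 and 4 are the only mirror pair shown, so it stays open whether inversion counts as much with another chain. Also open, going by these compounds, is how a chain ending in an amine or a carboxylic acid would compare.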